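The source may hold more compounds than are shown below. What is called first, only, known or untested is meant among the compounds shown, and "the series" means these compounds.

Of the compounds shown here, three sharing one core have been tested in an assay on HEK293 cells for positive allosteric modulation of metabotropic glutamate receptor 5 (Homo sapiens), read by FLIPR; a lower number here means that less compound is needed, a higher number that more compound is needed for the effect. Compound 1 `O=C(N1CCCCC1)N1CC(c2nc(-c3cccc(Cl)c3)no2)C1` gives 370 nM. Compound 3 `O=C(C1CCC2(CCC2)CC1)N1CC(c2nc(-c3cccc(Cl)c3)no2)C1` gives 1100 nM, the higher of the two numbers, and the step of a 3.0-fold higher number from compound 1 to compound 3 (0.47 log units; beyond the scatter) separates them. Compound 2 `O=C(C1CCCO1)N1CC(c2nc(-c3cccc(Cl)c3)no2)C1` gives only a limit of the assay, > 10000 nM. The step of an at least 27-fold higher number from compound 1 to compound 2 (1.43 log units; beyond the scatter) therefore marks the largest change seen so far.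

Compound 4 `COC1CCN(C(=O)N2CC(c3nc(-c4cccc(Cl)c4)no3)C2)CC1` has not been measured. It differs from compound 3 by a group of 8 heavy atoms (6 carbon, 1 nitrogen, 1 oxygen; one six-membered non-aromatic ring with 1 hetero atom) in place of a group of 9 heavy atoms (9 carbon; one four-membered non-aromatic ring of carbon only, one six-membered non-aromatic ring of carbon only), on a carbonyl carbon. This change brings back the kind of ring-nitrogen urea that compound 1 carries, with a methoxy group added to the piperidine, so the step that bears on it is a 3.0-fold higher number from compound 1 to compound 3 (0.47 log units; beyond the scatter), run in the opposite direction. A modest lowering of the number is therefore expected, roughly undoing that step, a 2.8-fold lower number from compound 3 to compound 4 (0.44 log units; beyond the scatter). The expected value for compound 4 is 400 nM, with a likely range from 150 nM to 1500 nM.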

Compound 4, half-maximal effective concentration: > 10000 nM
Compound 4 gave a limit, no number; the forecaster's own chance of this, stated with the estimate: 5%; middle value at least 25-fold (1.39 log units) away from the limit.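

Adding one methoxy on a saturated ring carbon of the piperidine in compound 1 is enough to lose a readable effect in this assay: an at least 27-fold higher number from compound 1 to compound 4 (1.43 log units; beyond the scatter). The carbon-only group of compound 3 keeps a readable value, so a ring nitrogen on this carbonyl carbon does not by itself secure the effect: an at least 9.0-fold higher number from compound 3 to compound 4 (0.95 log units; beyond the scatter). Compound 4 gives a limit and not a number, and the two compounds whose groups carry an oxygen atom, compound 2 and compound 4, both end there: the limit of > 10000 nM in this assay, at which 2 of the 4 values shown sit.

The step between compound 2 and compound 4 cannot be read, since both values are limits. The compounds shown cannot separate the oxygen atom from the mere presence of a group on that ring carbon, a distinction that a methyl or a fluoro group in place of the methoxy would address.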